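The source may report more compounds than this note shows. Statements on the series, on what has been measured and on what is new or still open speak of the compounds shown alone.

In a functional assay on HEL cells (Homo sapiens) for cytotoxicity (a lower number here means that less compound is tolerated, a higher number that more compound is tolerated), compound 3 (`CCCCCCCCC#Cc1cc2cn([C@@H]3O[C@H](CO)[C@@H](O)[C@H]3O)c(=O)nc2o1`) gives 62000 nM. Compound 2 (`CCCCCCCCCCC#Cc1cc2cn([C@H]3C[C@H](O)[C@@H](CO)O3)c(=O)nc2o1`) gives 36000 nM, within the scatter of compound 3. Compound 1 (`CCCCC#Cc1cc2cn([C@@H]3O[C@H](CO)[C@@H](O)[C@H]3O)c(=O)nc2o1`) gives > 144000 nM, and this value is a limit of the assay.

Compound 4 (`CCCCCCCCCCC#Cc1cc2cn([C@@H]3O[C@H](CO)[C@@H](O)[C@H]3O)c(=O)nc2o1`) differs from compound 3 by ethyl in place of hydrogen on a saturated chain carbon, eight bonds along the chain from a triple-bonded carbon.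

Within the data shown here, one measured step bears directly on this change. Butyl in place of hydrogen on the same chain gives an at least 2.3-fold lower number from compound 1 to compound 3 (0.36 log units; beyond the scatter). The size of that step is only a bound, since compound 1 stands at the limit of > 144000 nM in this assay, at which 1 of the 3 values shown sits. It is also a single step, so it sets a direction rather than a trend. The ethyl change adds fewer carbons than that butyl change, so a smaller move in the same direction is the working expectation, at or near the edge of the scatter. The value of compound 2 at 36000 nM also argues against a large drop.

The expected step is a 1.5-fold lower number from compound 3 to compound 4 (0.17 log units; within the scatter). Compound 4 is expected at 42000 nM, with an estimated range of 19000 nM to 90000 nM.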

Compound 4, half-maximal cytotoxic concentration: 44000 nM
Compound 4: middle estimate off by 1.0-fold (0.02 log units), on the low side, and the stated range covers the measured number.
By their numbers in this assay, from the lowest: compounds 2, 4 and 3 (each within the scatter of the next). At a limit, above all of these: compound 1.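

In this assay, ethyl in place of hydrogen on a saturated chain carbon, eight bonds along the chain from a triple-bonded carbon, gives a 1.4-fold lower number from compound 3 to compound 4 (0.15 log units; within the scatter), so this change does not separate compound 4 from compound 3. Hydroxy in place of hydrogen on a saturated ring carbon gives a 1.2-fold higher number from compound 2 to compound 4 (0.09 log units; within the scatter), the first comparison in the series that holds the chain constant and changes only the ring, and it too stays within the scatter. The only new step beyond the scatter is an at least 3.2-fold lower number from compound 1 to compound 4 (0.51 log units; beyond the scatter), and it starts from a limit, so its size is a bound only: the limit of > 144000 nM in this assay, at which 1 of the 4 values shown sits.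

Open, as far as these compounds go, is whether a longer chain than that of compound 4, or a chain ending in an amine or a carboxylic acid, would give a number outside the scatter of compound 3 and compound 4. Also open, from the compounds shown here alone, is the chain length, between that of compound 1 and that of compound 3, at which a measurable number first appears in place of the limit.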